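Sec-butoxy for ethylsulfanyl on the carbonyl of compound 2

The source may hold more compounds than are shown below. What is called first, only, known or untested is meant among the compounds shown, and "the series" means these compounds.

Compound 1 `CC1=C(C(=O)C2CC2)C(c2ccsc2)NC(=O)N1`: 1%
Compound 2 `CCSC(=O)C1=C(C)NC(=O)NC1c1ccsc1`: 17%

In an assay on membranes from HEK293 cells for displacement of a labelled ligand from adenosine receptor A2b (Homo sapiens), read by scintillation counting, with a stated time of 30 min, tested at 1 uM (on this read-out lower numbers stand for less inhibition and higher numbers for more inhibition at the one concentration tested (going by the name of the read-out)), compound 2 gives the highest of the two numbers, with compound 1 the nearer neighbour by a number 16 percentage points higher from compound 1 to compound 2 (beyond the scatter). Compound 3 `CCC(C)OC(=O)C1=C(C)NC(=O)NC1c1ccsc1` differs from compound 2 by sec-butoxy in place of ethylsulfanyl on a carbonyl carbon. Going by the values given here, the only measured step, from compound 1 to compound 2, exchanged a cyclopropyl for an ethylsulfanyl at the same carbonyl carbon and was modest; no step swaps an ethylsulfanyl for a sec-butoxy, so it bears on compound 3 only loosely. Compound 3 is therefore expected to sit near compound 2, with a step of a number 2 percentage points lower from compound 2 to compound 3 (within the scatter) that lies within the scatter. The estimate for compound 3 is 15%, between 0% and 35%.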

Compound 3, a percentage reported as inhibition, at one concentration (the size of the read-out at that concentration, not a potency): 39%
For compound 3 the middle estimate is 24 percentage points below the measured one; measured number above the stated range.
By their numbers in this assay, from the lowest: compound 1; then compound 2; then compound 3.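

In this assay, the group on this carbonyl carbon matters more than the first step suggested: sec-butoxy in place of ethylsulfanyl gives a number 22 percentage points higher from compound 2 to compound 3 (beyond the scatter), and sec-butoxy in place of cyclopropyl gives a number 38 percentage points higher from compound 1 to compound 3 (beyond the scatter). Of the three groups compared here, sec-butoxy gives the highest number. Nothing at hand explains this rise.

The change swaps both the linking atom and the chain, and the compounds shown do not separate the two. An ethoxy group on the same carbonyl carbon would bear on that question.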